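Methyl ether loss on a bis-aryl chain carbon

The compounds below may be only part of what the source reports. "The series", "measured", "known", "first", "only" and "open" are said of these compounds alone.

Measured in a functional assay on HeLa cells (Homo sapiens) for cytotoxicity, read by WST assay, with a stated time of 48 h; a lower number here means a stronger inhibitor, a higher number a weaker inhibitor:
- Compound 1 `COc1cc(C(c2ccc(O)c(OC)c2)[C@@H](C)[C@@H](C)CO)ccc1O`: > 100000 nM, a limit of the assay
- Compound 2 `COC[C@H](C(C)C)C(c1ccc(O)c(OC)c1)c1ccc(O)c(OC)c1`: 76000 nM
- Compound 3 `COC[C@H](C)[C@@H](C)C(c1ccc(O)c(OC)c1)c1ccc(O)c(OC)c1`: 77000 nM

Among the measured compounds shown here, compound 3 stands level with the only other exact number, as a 1.0-fold higher number from compound 2 to compound 3 (0.01 log units; within the scatter) shows. Compound 4 `COc1cc(C(c2ccc(O)c(OC)c2)[C@@H](CO)C(C)C)ccc1O` differs from it by 1-(hydroxymethyl)-2-methylpropyl in place of 2-(methoxymethyl)-1-methylpropyl on a saturated chain carbon bound to two aromatic carbons. For the measured compounds named here, two measured steps bear on this, an at least 1.3-fold lower number from compound 1 to compound 2 (0.11 log units; that floor lies within the scatter) and an at least 1.2-fold lower number from compound 1 to compound 3 (0.11 log units; that floor lies within the scatter), each leading from a hydroxymethyl chain to a methoxymethyl chain and each giving only a floor. Compound 4 returns to a hydroxymethyl chain, so a small move the opposite way is expected in this assay. The estimated step is a 1.3-fold higher number from compound 3 to compound 4 (0.11 log units; within the scatter), toward a higher number. For compound 4 the expected value is 100000 nM, with an estimated range from 60000 nM to 170000 nM.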

Compound 4, half-maximal inhibitory concentration: > 100000 nM
Compound 4 was reported as a limit (the forecaster's own chance of this, stated with the estimate: 55%); the middle value lies on the limit itself.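

The 1-(methoxymethyl)-2-methylpropyl chain of compound 2 now has a hydroxymethyl partner on the same chain, giving an at least 1.3-fold higher number from compound 2 to compound 4 (0.11 log units; that floor lies within the scatter), and the comparison with the other methoxymethyl chain gives an at least 1.2-fold higher number from compound 3 to compound 4 (0.11 log units; that floor lies within the scatter); both floors lie within the scatter. Compound 1 and compound 4, the two hydroxymethyl chains shown, each stand at a limit rather than a number: the limit of > 100000 nM in this assay, at which 2 of the 4 values shown sit.

The step between compound 1 and compound 4 cannot be read. As far as these compounds go, whether an amine or a carboxylic acid in place of the hydroxymethyl would give an exact number remains open.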